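This account rests on a few compounds, and the source may have more. Where it says the series, first, only, none or still open, it means among the compounds named here.

Compound 1, `CC(C(=O)Nc1ccccc1)N1C(=O)CCC1=O`, is the reference point here. Going by the values given here, in a functional assay on the whole organism (strain Swiss) with Mus musculus as the target, in the maximal electroshock model (a higher number here means that more compound is needed for the effect, a lower number that less compound is needed), compound 1 gives 96.9 mg/kg, the lowest of the two numbers measured so far. Its nearest neighbour is compound 2, `CC(C(=O)Nc1cccc(Cl)c1)N1C(=O)CCC1=O`, which in this assay gives 105 mg/kg; the step of a 1.1-fold higher number from compound 1 to compound 2 (0.03 log units; within the scatter) is within the scatter, so the two compounds cannot be told apart on these numbers.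

Compound 3, `CCC(C(=O)Nc1ccccc1)N1C(=O)CCC1=O`, is still unmeasured. It differs from compound 1 in one place: methyl in place of hydrogen on a saturated chain carbon, two bonds along the chain from an amide-type nitrogen in a ring and a carbonyl carbon. Among the compounds with values here, no measured step touches this part of the molecule; the only measured step, a 1.1-fold higher number from compound 1 to compound 2 (0.03 log units; within the scatter), concerns a change on the aromatic ring and was within the scatter, so it gives no direct guidance on a change to the saturated chain. With nothing to point either way, the expectation is that compound 3 will land close to compound 1, with no step beyond the scatter.

The estimate is therefore that compound 3 gives 90 mg/kg in this assay, within a range from 45 mg/kg to 180 mg/kg. This expected result corresponds to the step of a 1.1-fold lower number from compound 1 to compound 3 (0.03 log units; within the scatter).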

Compound 3, dose for half-maximal effect: 116 mg/kg
Compound 3: middle estimate off by 1.3-fold (0.11 log units), on the low side, and the stated range covers the measured number.
By their numbers in this assay, from the lowest: compounds 1, 2 and 3 (each within the scatter of the next).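

Replacing hydrogen with methyl on a saturated chain carbon, two bonds along the chain from an amide-type nitrogen in a ring and a carbonyl carbon, turns the methyl of compound 1 into the ethyl of compound 3 and gives a 1.2-fold higher number from compound 1 to compound 3 (0.08 log units; within the scatter) in this assay, so the two compounds cannot be told apart on these numbers. Going by these compounds alone, this is the first reading at this chain position, since the earlier step concerned only the aromatic ring, and it shows that a methyl-to-ethyl change here leaves the dose needed for the effect indistinguishable from that of compound 1 within the usual scatter. Nothing available explains this result or says what this position does in the whole animal.

A single added carbon does not say how this position would respond to a longer chain such as propyl or butyl, a ring such as phenyl, or a group such as a hydroxyl or an amine. It also leaves open whether the ethyl and the chloro group, each indistinguishable from compound 1 on its own, would give the same reading when carried together on one molecule.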